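Substituted Piperidine Amides Against Thyroid Hormone Receptor Beta

A few compounds are considered here, and "the series" means these few. Any claim that something is new, unique, unknown or untested is made for them only; others in the source may bear on it.

Three amides built on a shared core were examined in an assay on isolated protein for inhibition of thyroid hormone receptor beta (Homo sapiens), read by fluorescence, with a stated time of 30 min; on this read-out lower numbers stand for stronger inhibition and higher numbers for weaker inhibition. Compound 1 `CCCN(CC1CCOC1)C(=O)c1cc(C)c2oc(NCc3cccc(Cl)c3)nc2c1` gives 35 nM in this assay. Compound 2 `COc1cc(C(=O)N2CCC(O)CC2)cc2nc(NCc3cccc(Cl)c3)oc12` gives 352 nM, the second highest of the three numbers; compound 1 lies beyond the scatter below it, while compound 3 `COc1cc(C(=O)N2CCC(O)C(C)C2)cc2oc(NCc3cccc(Cl)c3)nc12`, which gives 3900 nM, lies beyond the scatter above it. The unmeasured compound 4 `COc1cc(C(=O)N2CC(C)C(O)CC2CCO)cc2nc(NCc3cccc(Cl)c3)oc12` differs from compound 2 by 4-hydroxy-2-(2-hydroxyethyl)-5-methylpiperidin-1-yl in place of 4-hydroxypiperidin-1-yl on a carbonyl carbon. For the measured compounds named here, no measured pair isolates this change; compound 3 carries an extra methyl and shows the highest number, yet it also differs from compound 2 elsewhere. A weakening step is expected, from compound 2 to compound 4 of a 4.3-fold higher number from compound 2 to compound 4 (0.63 log units; beyond the scatter). Compound 4 is therefore expected to give about 1500 nM in this assay, within a range from 400 nM to 6000 nM.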

Compound 4, half-maximal inhibitory concentration: 0.27 nM
Compound 4: middle estimate off by 5600-fold (3.74 log units), on the high side; measured number outside the range, below it.
By their numbers in this assay, from the lowest: compound 4; then compound 1; then compound 2; then compound 3.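

In this assay, 4-hydroxy-2-(2-hydroxyethyl)-5-methylpiperidin-1-yl in place of 4-hydroxypiperidin-1-yl on a carbonyl carbon gives a 1300-fold lower number from compound 2 to compound 4 (3.12 log units; beyond the scatter) as a large step beyond the scatter. For the compounds shown here, this place therefore accepts a more substituted six-membered ring, and a change here alone can move the number a long way down, which no earlier pair could show. Nothing available explains the step. The 2-hydroxyethyl and the methyl arrive together, so their separate shares remain unresolved. On these data alone, whether an amine or a longer chain in place of the 2-hydroxyethyl would keep this number also remains open.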